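This account rests on a few compounds, and the source may have more. Where it says the series, first, only, none or still open, it means among the compounds named here.

Working notes on the series. All four members share one core; the read-out of interest is a functional assay on U-87MG ATCC cells for antiproliferative activity against U-87 MG (Homo sapiens), read by MTT assay, with a stated time of 48 h, tested at 50 uM; a higher number here means a weaker effect of the compound at the concentration tested, a lower number a stronger effect. Compound 1 `Cc1nc(-c2ccc(Cl)cc2)sc1C(=O)CSc1nc(-c2ccccc2)c(C#N)c(=O)[nH]1` gives 41.6% in this assay. Going by the values given here, compound 2 `Cc1nc(-c2ccc(Cl)cc2)sc1C(=O)CSc1nc(-c2cccc(Cl)c2)c(C#N)c(=O)[nH]1` gives 52.6% in this assay; the one measured step is a number 11 percentage points higher from compound 1 to compound 2 (beyond the scatter), a modest weakening of effect. Compound 3 `COc1ccc(-c2nc(SCC(=O)c3sc(-c4ccccc4)nc3C)[nH]c(=O)c2C#N)cc1OC` gives 21.4% in this assay, the lowest of the three numbers and so the strongest effect at the concentration tested; compound 1 stands nearest to it and compound 2 furthest, both gaps beyond the scatter.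

Compound 4 `COc1ccc(-c2nc(SCC(=O)c3sc(-c4ccc(Cl)cc4)nc3C)[nH]c(=O)c2C#N)cc1OC` has not yet been measured in this assay. Among the compounds with values here, it differs from compound 3 by chloro in place of hydrogen on an aromatic carbon, the same kind of change as the one measured step, which went as a number 11 percentage points higher from compound 1 to compound 2 (beyond the scatter). Within the data shown here, that step is the only guide available, and it points to a modest weakening beyond the scatter, though a result within the scatter cannot be excluded from a single precedent. A rise of roughly that size is therefore expected, a number 8.6 percentage points higher from compound 3 to compound 4 (within the scatter). Compound 4 is estimated at 30% in this assay, with a range from 16% to 46%.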

Compound 4, a percentage reported as activity, at one concentration (the size of the read-out at that concentration, not a potency): 59.8%
The estimate for compound 4 lay 29.8 percentage points below the measured number; measured number outside the range, above it.
By their numbers in this assay, from the lowest: compound 3; then compound 1; then compounds 2 and 4 (each within the scatter of the next).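

In this assay, phenyl to 4-chlorophenyl on the core of compound 3 is a far larger step than the earlier chloro step, so the size of this change is not constant across the series: the same change on two cores in this assay, a number 11 percentage points higher (beyond the scatter) from compound 1 to compound 2 and a number 38.4 percentage points higher (beyond the scatter) from compound 3 to compound 4, 27.4 percentage points apart, beyond the scatter of two such steps. With 4-chlorophenyl held in place, 3,4-dimethoxyphenyl in place of phenyl gives a number 18.2 percentage points higher from compound 1 to compound 4 (beyond the scatter) and in place of 3-chlorophenyl gives a number 7.2 percentage points higher from compound 2 to compound 4 (within the scatter), so the dimethoxy-substituted group brings no stronger effect in either pair. Going by these compounds alone, the step of a number 38.4 percentage points higher from compound 3 to compound 4 (beyond the scatter), the only pair that tests this position with 3,4-dimethoxyphenyl present, ties the strong effect of compound 3 to hydrogen rather than chloro on that aromatic carbon.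

The two chloro steps sit on different aryl groups, so the compounds shown do not separate the influence of the partner group from that of the place where chloro enters. From the compounds shown here alone, whether the large step is particular to chloro also stays open, and a methoxy group, an amine or a carboxylic acid on the same aromatic carbon would begin to answer that.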